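From Compound 3 to Compound 4: Extending the Alkyl Chain

This account rests on a few compounds, and the source may have more. Where it says the series, first, only, none or still open, it means among the compounds named here.

Of the compounds shown here, three sharing one core have been tested in an assay on isolated protein for inhibition of ATP-dependent RNA helicase SUPV3L1, mitochondrial (Homo sapiens); a lower number here means a stronger inhibitor, a higher number a weaker inhibitor. Compound 1 `CCCCCCCCCCCCCCNc1nc(=O)c2ncn([C@@H]3O[C@H](CO)[C@@H](O)[C@H]3O)c2c(=O)[nH]1` gives 30 ug/mL, and compound 2 `CCCCCCCCCCCCCCCCCCNc1nc(=O)c2ncn([C@@H]3O[C@H](CO)[C@@H](O)[C@H]3O)c2c(=O)[nH]1` gives 30 ug/mL. Compound 3 `CCCCCCCCCCNc1nc(=O)c2ncn([C@@H]3O[C@H](CO)[C@@H](O)[C@H]3O)c2c(=O)[nH]1` gives 500 ug/mL, the highest of the three numbers. Both a 17-fold higher number from compound 1 to compound 3 (1.22 log units; beyond the scatter) and a 17-fold higher number from compound 2 to compound 3 (1.22 log units; beyond the scatter) are large rises, whereas no change at the digits printed from compound 1 to compound 2 (within the scatter). Compound 4 `CCCCCCCCCCCCNc1nc(=O)c2ncn([C@@H]3O[C@H](CO)[C@@H](O)[C@H]3O)c2c(=O)[nH]1` differs from compound 3 by ethyl in place of hydrogen on a saturated chain carbon, ten or more bonds along the chain from a nitrogen on an aromatic ring. Because a 17-fold higher number from compound 1 to compound 3 (1.22 log units; beyond the scatter) was large, while the added ethyl here is shorter than the butyl of that step, compound 4 is expected to recover only part of the gap, so that a 5.0-fold lower number from compound 3 to compound 4 (0.70 log units; beyond the scatter) is anticipated. Compound 4 is therefore estimated at 100 ug/mL, with a likely range from 30 ug/mL to 400 ug/mL.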

Compound 4, half-maximal inhibitory concentration: 150 ug/mL
The estimate for compound 4 lay 1.5-fold (0.18 log units) below the measured number, and the stated range covers the measured number.
By their numbers in this assay, from the lowest: compounds 1 and 2 (each within the scatter of the next); then compound 4; then compound 3.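

Adding ethyl at this saturated chain carbon brings only a partial recovery (a 3.3-fold lower number from compound 3 to compound 4 (0.52 log units; beyond the scatter)), and compound 4 still falls short of the two longer chains (a 5.0-fold higher number from compound 1 to compound 4 (0.70 log units; beyond the scatter); a 5.0-fold higher number from compound 2 to compound 4 (0.70 log units; beyond the scatter)). Among these compounds the number falls in stages as the chain lengthens from compound 3 through compound 4 to compound 1, then flattens (no change at the digits printed from compound 1 to compound 2 (within the scatter)). No evidence on the cause of this dependence on chain length is available.

Still open, going by these compounds, is how a chain ending in an amine or a carboxylic acid would behave at this position, and whether a still longer chain would hold the number level.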